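The source may report more compounds than this note shows. Statements on the series, on what has been measured and on what is new or still open speak of the compounds shown alone.

Series notes. Compound 1, `COc1ccc(C(=C/C=C/C(=O)NCCCCc2cccnc2)c2ccc(OC)c(OC)c2)cc1OC`, and compound 3, `COc1ccc(C(=C/C=C/C(=O)N[C@H](C)CCCc2cccnc2)c2ccc(OC)c(OC)c2)cc1OC`, share one core and differ in a single place: methyl in place of hydrogen on a saturated chain carbon bound to an amide-type nitrogen and a saturated chain carbon. In an assay (Canis lupus familiaris) for binding affinity to platelet-activating factor receptor (Homo sapiens), read by radioligand binding (a higher number here means a weaker inhibitor, a lower number a stronger inhibitor), compound 1 gives 55 nM. Compound 3 gives 50 nM in this assay. The step between them is a 1.1-fold lower number from compound 1 to compound 3 (0.04 log units; within the scatter), so the two values cannot be told apart here.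

Compound 2, `COc1cccc(C(=C/C=C/C(=O)NCCCCc2cccnc2)c2cccc(OC)c2)c1`, is built on another core; the difference between the core of compound 2 and the core of compound 1 is not broken down here. In this assay compound 2 gives 2 nM, the lowest of the three numbers, with compound 3 and compound 1 both beyond the scatter above it.

Compound 4, `COc1cccc(C(=C/C=C/C(=O)N[C@H](C)CCCc2cccnc2)c2cccc(OC)c2)c1`, is not yet measured in this assay. It stands to compound 2 as compound 3 stands to compound 1: methyl in place of hydrogen on a saturated chain carbon bound to an amide-type nitrogen and a saturated chain carbon, the same change made on the core of compound 2. Among the measured compounds shown here, the one measured instance of this change, from compound 1 to compound 3, moved the number by a 1.1-fold lower number from compound 1 to compound 3 (0.04 log units; within the scatter). The step from compound 2 to compound 4 is expected to be of like size, a 1.1-fold higher number from compound 2 to compound 4 (0.04 log units; within the scatter), resting on that single prior step a 1.1-fold lower number from compound 1 to compound 3 (0.04 log units; within the scatter). The expectation carries the caveat that the change has been seen only once and only on the other core. Compound 4 is therefore expected to give about 2.2 nM in this assay. The expected range for compound 4 runs from 0.9 nM to 5.5 nM.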

Compound 4, half-maximal inhibitory concentration: 35 nM
Estimate against measurement, compound 4: 16-fold (1.20 log units) below, and the stated range ends below it.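

In this assay, adding the methyl on the core of compound 2 is a large step, an 18-fold higher number from compound 2 to compound 4 (1.24 log units; beyond the scatter), so the low number of that core does not survive the change. Among the compounds shown here, the size of this step therefore does not transfer between the two cores, and the two instances clearly differ: the same change on two cores in this assay, a 1.1-fold lower number (0.04 log units; within the scatter) from compound 1 to compound 3 and an 18-fold higher number (1.24 log units; beyond the scatter) from compound 2 to compound 4, 19-fold (1.28 log units) apart, beyond the scatter of two such steps This rests on only two matched pairs, so it shows that the effect of the methyl depends on the core it sits on, but it does not show which feature of the cores is responsible, how the change would behave on any third core, or why the two steps differ.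

The compounds shown leave open whether a larger group at the same place, such as ethyl, or the opposite configuration at the methyl-bearing carbon would also separate the two cores. They also leave open whether a longer chain in place of 1-methyl-4-(pyridin-3-yl)butyl would follow the same core dependence, and whether intermediate cores, carrying only part of the difference between the core of compound 1 and the core of compound 2, would locate where the response to the methyl changes.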